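The source may report more compounds than this note shows. Statements on the series, on what has been measured and on what is new or still open speak of the compounds shown alone.

In a functional assay on MES-SA/Dx5 cells (Homo sapiens) for inhibition, read by fluorescence, with a stated time of 72 h (a higher number here means a weaker inhibitor, a lower number a stronger inhibitor), compound 1 (`FC(F)(F)c1cccc(NC(=S)N/N=C/c2ccccn2)c1`) gives 692 nM; 720 nM (2 entries) across its entries and compound 2 (`Oc1ccccc1/C=N/NC(=S)Nc1ccccc1`) gives 4790 nM; 6450 nM (2 entries) across its entries. Compound 3 (`Oc1ccccc1/C=N/NC(=S)Nc1cccc(C(F)(F)F)c1`) stands at 4080 nM as its only number shown, and two further entries for it give no single number. That value lies within the usual scatter of those of compound 2 and well apart from those of compound 1. The change to compound 4 (`O=[N+]([O-])c1ccc(O)c(/C=N/NC(=S)Nc2cccc(C(F)(F)F)c2)c1`) is nitro in place of hydrogen on an aromatic carbon and the nitro sits para to a hydroxy group. For the measured compounds named here, no measured pair isolates a change at this place. The step expected is a 1.2-fold lower number from compound 3 to compound 4 (0.07 log units; within the scatter) in this assay and that estimate lies within the scatter. Compound 4 is expected at 3500 nM (estimated range 1200 nM to 10000 nM).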

Compound 4, half-maximal inhibitory concentration: 11900 nM
Estimate against measurement, compound 4: 3.4-fold (0.53 log units) below; the measured number lies above the stated range.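

In this assay, nitro in place of hydrogen on an aromatic carbon, para to a hydroxy group, gives a 2.9-fold higher number from compound 3 to compound 4 (0.46 log units; beyond the scatter). For the compounds shown here, this is the first step between compounds that differ in one place, and it shows that this position is not silent: the change weakens inhibition beyond the scatter. No measurement shown gives a reason for the step. Open, from the compounds shown here alone, is whether an amine or a methoxy group on the same carbon moves the number in the same direction. Also open, going by these compounds, is whether nitro has a similar effect elsewhere on that ring.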